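This account rests on a few compounds, and the source may have more. Where it says the series, first, only, none or still open, it means among the compounds named here.

In an ADME assay on U2OS cells (Homo sapiens) for cytotoxicity (a higher number here means that more compound is tolerated, a lower number that less compound is tolerated), compound 1 `CCCCCCc1ccc(C(=O)N/N=C/c2ccc([N+](=O)[O-])o2)cc1` gives only a limit of the assay, > 200000 nM. For the measured compounds named here, compound 2 `CCCCc1ccc(C(=O)N/N=C/c2ccc([N+](=O)[O-])o2)cc1` gives 19600 nM, and the single measured step is an at least 10-fold lower number from compound 1 to compound 2 (1.00 log units; beyond the scatter). Compound 3 `CCCCCCC1CCC(C(=O)N/N=C/c2ccc([N+](=O)[O-])o2)CC1` likewise gives only a limit, > 200000 nM. Two of the three values therefore sit at the limit of > 200000 nM in this assay, at which 2 of the 3 values shown sit, so compound 3 stands at the upper edge of what the assay reports. Compound 4 `O=C(N/N=C/c1ccc([N+](=O)[O-])o1)C1CCCCC1` differs from compound 3 by hydrogen in place of hexyl on a saturated ring carbon. The step from compound 1 to compound 2 bears on this, since there too a chain was shortened and the number fell; removing the whole hexyl is a larger change, so a downward step beyond the scatter is expected, an at least 6.6-fold lower number from compound 3 to compound 4 (0.82 log units; beyond the scatter). Compound 4 is thus estimated at 30000 nM, between 8000 nM and 150000 nM.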

Compound 4, half-maximal cytotoxic concentration: 25400 nM
Beside the measured number, compound 4's estimate is 1.2-fold (0.07 log units) above it, and the stated range covers the measured number.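

In this assay, the step on a saturated ring carbon is an at least 7.8-fold lower number from compound 3 to compound 4 (0.89 log units; beyond the scatter), beyond the scatter. The earlier step concerned a chain on an aromatic carbon, so a lower number on losing carbon chain now appears on the saturated ring as well, here with the whole hexyl replaced by hydrogen. Compound 3 gives only a limit, so the full size of this step cannot be read: the limit of > 200000 nM in this assay, at which 2 of the 4 values shown sit.

The compounds shown leave open how a shorter chain on that saturated ring carbon would read, and whether an amine or a carboxylic acid there would give a higher or lower number than hydrogen.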